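Swapping an Aryl Group on a Fused Core

The source may hold more compounds than are shown below. What is called first, only, known or untested is meant among the compounds shown, and "the series" means these compounds.

Measured compounds:
compound 1 `Brc1cn2ccnc2c(-c2ccc3ncn(C4CCCCC4)c3c2)n1`: 10.2%
compound 2 `CC(=O)c1ccc(-c2cn3ccnc3c(-c3ccc4ncn(C5CCCCC5)c4c3)n2)cc1`: 0.58%
compound 3 `Brc1ccc(-c2cn3ccnc3c(-c3ccc4ncn(C5CCCCC5)c4c3)n2)cc1`: 24.1%

Three compounds share one core and differ only in the group carried on a single aromatic carbon. In a functional assay on SK-MEL-2 cells (Homo sapiens) for inhibition, read by sulforhodamine B assay, with a stated time of 48 h, tested at 10 uM (a lower number here means less inhibition, a higher number more inhibition at the concentration tested (going by the name of the read-out)), compound 3 gives 24.1%, the highest of the three; compound 1 gives 10.2% and compound 2 gives 0.58%. The steps are a number 13.9 percentage points higher from compound 1 to compound 3 (beyond the scatter), a number 23.5 percentage points higher from compound 2 to compound 3 (beyond the scatter) and a number 9.6 percentage points lower from compound 1 to compound 2 (within the scatter).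

Compound 4 `Fc1ccccc1-c1cn2ccnc2c(-c2ccc3ncn(C4CCCCC4)c3c2)n1` differs from compound 3 by 2-fluorophenyl in place of 4-bromophenyl on an aromatic carbon. Among the compounds with values here, no measured step involves a 2-fluorophenyl, so the two steps that lead into compound 3 are the only guide, and they show that changing the group at this place shifts the read-out by modest amounts in either direction. Since compound 1 gives 10.2% and compound 2 gives 0.58%, the expected step of a number 10.1 percentage points lower from compound 3 to compound 4 (beyond the scatter) is a modest fall back toward those levels. Compound 4 is therefore estimated at 14%, with a range from 0% to 32%.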

Compound 4, a percentage reported as inhibition, at one concentration (the size of the read-out at that concentration, not a potency): 10.5%
Compound 4: the middle estimate sits 3.5 percentage points above what was measured, within the range that was stated.
By their numbers in this assay, from the lowest: compounds 2, 1 and 4 (each within the scatter of the next); then compound 3.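

Exchanging one substituted phenyl for another at this position, with the same heavy-atom count in the group that leaves and the group that enters, is enough to give a number 13.6 percentage points lower from compound 3 to compound 4 (beyond the scatter) in this assay, so carrying a phenyl ring here does not by itself secure the higher number of compound 3. The 2-fluorophenyl group also cannot be told apart from the bromo or 4-acetylphenyl groups, with a number 0.3 percentage points higher from compound 1 to compound 4 (within the scatter) and a number 9.9 percentage points higher from compound 2 to compound 4 (within the scatter). No measurement at hand explains why the two phenyl groups differ.

This change replaces bromine with fluorine and also moves the halogen on the phenyl ring, so the compounds shown cannot separate those two changes. Going by these compounds, how a phenyl ring carrying an amine or a carboxylic acid would read at this position also remains open.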